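Swapping an Ester for a Pyrrolidine on a Shared Core

The compounds below may be only part of what the source reports. "The series", "measured", "known", "first", "only" and "open" are said of these compounds alone.

Compound 2 `CC(C)OC(=O)c1ccc(NCc2cncn2Cc2ccc(-c3ccccc3)cc2)cc1-c1ccccc1` was tested in a toxicity assay on NIH3T3 cells (Mus musculus) for cytotoxicity, read by resazurin assay; a lower number here means that less compound is needed, a higher number that more compound is needed for the effect. In this assay compound 2 gives > 10000 nM, which is a limit of the assay rather than a number, matching (the limit of > 10000 nM in this assay, at which 1 of the 2 values shown sits). Compound 1 `COC(=O)c1ccc(NCc2cncn2Cc2ccccc2OC)cc1-c1ccccc1` has in this assay "not determined" (no result reported). Compound 3 `c1ccc(-c2ccc(Cn3cncc3CNc3ccc(N4CCCC4)c(-c4ccccc4)c3)cc2)cc1` is not yet measured; it differs from compound 2 by pyrrolidin-1-yl in place of isopropoxycarbonyl on an aromatic carbon. For the measured compounds named here, no step between measured compounds is available to judge this change. For compound 3 the expected step is a step that the limit leaves unreadable from compound 2 to compound 3, none beyond the scatter. Compound 3 is estimated at 15000 nM, between 5000 nM and 50000 nM.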

Compound 3, half-maximal effective concentration: > 1000 nM
Compound 3 gave a limit, no number; the forecaster's own chance of this, stated with the estimate: 70%; the middle value does not contradict the limit.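

For the compounds shown here, compound 2 and compound 3 each gave only a limit, not a number, and no step between them can be read. The compounds shown leave open whether pyrrolidin-1-yl in place of isopropoxycarbonyl changes the concentration needed for the effect.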